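Cytotoxicity limits in the series and the loss of cyano

A few compounds are considered here, and "the series" means these few. Any claim that something is new, unique, unknown or untested is made for them only; others in the source may bear on it.

Measured in an ADME assay on J774 cells (Mus musculus) for cytotoxicity; a lower number here means that less compound is needed, a higher number that more compound is needed for the effect:
- Compound 1 `COC(=O)c1c[nH]c2cc(OCCOc3ccccc3)c(C)cc2c1=O`: > 20000 nM (a limit)
- Compound 2 `CCCCc1cc2c(=O)c(C#N)c[nH]c2cc1OCCOc1ccccc1`: > 20000 nM (a limit)

Neither measured compound gives a number, and the series shows only (the limit of > 20000 nM in this assay, at which 2 of the 2 values shown sit). Compound 2 stands at > 20000 nM, which is a limit of the assay and not a number.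

Compound 3 `CCCCc1cc2c(=O)cc[nH]c2cc1OCCOc1ccccc1` carries hydrogen in place of cyano on an aromatic carbon. With compound 2 at > 20000 nM, no change beyond the usual scatter is expected in this assay. The estimated a number no higher from compound 2 to compound 3 (the limit leaves the size open) therefore has no clear direction. Compound 3 is expected at 20000 nM, with an estimated range of 10000 nM to 40000 nM.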

Compound 3, half-maximal effective concentration: > 20000 nM
Compound 3: only a limit was reported (the forecaster's own chance of this, stated with the estimate: 75%); the middle value sits exactly at the limit.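

No step can be read from compound 2 to compound 3: each value is a limit and not a number. The compounds shown leave open the concentration at which any of them would give a measurable effect in this assay: the limit of > 20000 nM in this assay, at which 3 of the 3 values shown sit.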